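A few compounds are considered here, and "the series" means these few. Any claim that something is new, unique, unknown or untested is made for them only; others in the source may bear on it.

Compound 1 `CC(=O)Nc1ccc2oc(-c3ccccc3)cc(=O)c2c1`: 184000 nM
Compound 2 `CC(=O)Nc1ccc2oc(-c3ccccc3F)cc(=O)c2c1`: 205000 nM

In an ADME assay on MT4 cells (Homo sapiens) for cytotoxicity, read by MTT assay, with a stated time of 4 days (on this read-out higher numbers stand for lower toxicity in this test and lower numbers for higher toxicity in this test), compound 2 at 205000 nM cannot be told apart from compound 1. Compound 3 `Nc1ccc2oc(-c3ccccc3F)cc(=O)c2c1` differs from compound 2 by hydrogen in place of acetyl on a nitrogen on an aromatic ring, acetamido to amino. Among the measured compounds shown here, the only measured step, a 1.1-fold higher number from compound 1 to compound 2 (0.05 log units; within the scatter), is a different change, fluoro in place of hydrogen on an aromatic carbon, so it bears only indirectly. No change on this nitrogen has been measured, so the expectation is tentative: a moderate move to a lower number in this assay, with no change beyond the scatter still possible. The expected step is a 1.7-fold lower number from compound 2 to compound 3 (0.23 log units; within the scatter). For compound 3 the estimated value is 120000 nM, with an expected range of 40000 nM to 280000 nM.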

Compound 3, half-maximal cytotoxic concentration: 283000 nM
The estimate for compound 3 lay 2.4-fold (0.37 log units) below the measured number, and the stated range ends below it.
By their numbers in this assay, from the lowest: compounds 1, 2 and 3 (each within the scatter of the next).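

In this assay, the change from acetamido to amino on the nitrogen on the aromatic ring gives a 1.4-fold higher number from compound 2 to compound 3 (0.14 log units; within the scatter), so the acetyl can leave this nitrogen with no shift beyond the scatter. Among the compounds shown here, this is the first reading at this position, and with the earlier fluoro step it leaves all three compounds within the scatter of the next. No available evidence bears on this result.

On these data alone, whether a longer acyl chain, a methyl or a sulfonyl group on this nitrogen would behave the same stays open. Also open, as far as these compounds go, is how the amino form reads without the fluoro.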